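The source may report more compounds than this note shows. Statements on the series, on what has been measured and on what is new or still open speak of the compounds shown alone.

Measured compounds:
compound 1 `CCC1C(=O)N(C)c2cnc(-n3ccc4cc(C(=O)NC)ccc43)nc2N1c1ccn(C)n1`, 218 nM
compound 2 `CCC1C(=O)N(C)c2cnc(-n3ccc4cc(F)ccc43)nc2N1c1ccn(C)n1`, 1500 nM
compound 3 `CC[C@@H]1C(=O)N(C)c2cnc(-n3ccc4cc(F)ccc43)nc2N1C1CCCC1`, 969 nM

These three compounds were tested in an assay for inhibition of serine/threonine-protein kinase PLK2 (Homo sapiens), read by FRET and Z'-LYTE, with a stated time of 1 h; a lower number here means a stronger inhibitor, a higher number a weaker inhibitor. Compound 2 and compound 1 share one core and differ only on the fused ring system, where compound 1 carries a methylcarbamoyl group instead of fluoro (methylcarbamoyl in place of fluoro on an aromatic carbon). This change gave a 6.9-fold lower number from compound 2 to compound 1 (0.84 log units; beyond the scatter). Compound 3 has a different core from compound 2; how the two cores differ is not broken down here. In this assay compound 3 gives 969 nM, which sits close to compound 2 and is within the scatter of it.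

Compound 4 `CC[C@@H]1C(=O)N(C)c2cnc(-n3ccc4cc(C(=O)NC)ccc43)nc2N1C1CCCC1` is not yet measured. It relates to compound 3 exactly as compound 1 relates to compound 2: the same change, methylcarbamoyl in place of fluoro, at the same place (methylcarbamoyl in place of fluoro on an aromatic carbon). Because compound 3 starts at 969 nM and the earlier change gave a 6.9-fold lower number from compound 2 to compound 1 (0.84 log units; beyond the scatter), a step of similar size is expected here, a 6.1-fold lower number from compound 3 to compound 4 (0.78 log units; beyond the scatter). The estimate for compound 4 in this assay is 160 nM, expected to fall between 60 nM and 450 nM.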

Compound 4, half-maximal inhibitory concentration: 8.6 nM
The estimate for compound 4 lay 19-fold (1.27 log units) above the measured number, outside the stated range (below it).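

In this assay, putting methylcarbamoyl in place of fluoro on the core of compound 3 gave a 110-fold lower number from compound 3 to compound 4 (2.05 log units; beyond the scatter), so the change lowered the number on both cores tested. The direction carried over from one core to the other, but the size did not: the same change on two cores in this assay, a 6.9-fold lower number (0.84 log units; beyond the scatter) from compound 2 to compound 1 and a 110-fold lower number (2.05 log units; beyond the scatter) from compound 3 to compound 4, 16-fold (1.21 log units) apart, beyond the scatter of two such steps These results do not show which feature of the core of compound 3 goes with the larger step, as the two cores are not broken down into single differences, and two cores are too few to predict the size of the step on a third.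

The compounds shown leave open whether another group on the same aromatic carbon, such as a nitrile, a carboxylic acid or a longer amide like ethylcarbamoyl, would match methylcarbamoyl. They also leave open whether the amide hydrogen matters, a question that a dimethylcarbamoyl group on the same carbon could address.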